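A few compounds are considered here, and "the series" means these few. Any claim that something is new, unique, unknown or untested is made for them only; others in the source may bear on it.

Measured compounds in a functional assay on SNB-75 cells (Homo sapiens); a higher number here means a weaker inhibitor of growth, a lower number a stronger inhibitor of growth:
compound 1 `COc1cc(CSc2cc(Cl)c(-c3nnc(-c4ccc(Cl)cc4)s3)cc2S(=O)(=O)NC(=N)NO)cc(OC)c1OC`, 25700 nM
compound 2 `COc1cc(CSc2cc(Cl)c(-c3nnc(-c4ccccc4)s3)cc2S(=O)(=O)NC(=N)NO)cc(OC)c1OC`, 1860 nM

Compound 2 stands lowest of the two numbers in this assay, with compound 1 nearest at a markedly higher value. Within the data shown here, the one measured step, a 14-fold lower number from compound 1 to compound 2 (1.14 log units; beyond the scatter), came from a single change: hydrogen in place of chloro on an aromatic carbon.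

Compound 3 `COc1cc(CSc2cc(Cl)c(-c3nc(-c4ccc(Cl)cc4)no3)cc2S(=O)(=O)NC(=N)NO)cc(OC)c1OC` differs from compound 2 as follows: 3-(4-chlorophenyl)-1,2,4-oxadiazol-5-yl in place of 5-phenyl-1,3,4-thiadiazol-2-yl on an aromatic carbon. Two things move at once. Among the measured compounds shown here, a chloro group returns to the outer phenyl ring, the very substituent whose removal gave the large step from compound 1 to compound 2, and the five-membered ring with three hetero atoms changes from a thiadiazole to an oxadiazole, a change on which no measured pair gives any information. Only the chloro-bearing step bears on this case, and it argues for a higher number.

Compound 3 is therefore expected to give a weaker inhibition of growth than compound 2, estimated at 12000 nM with a range of 3000 nM to 40000 nM, a step of a 6.5-fold higher number from compound 2 to compound 3 (0.81 log units; beyond the scatter), the width of the range reflecting the untested ring change.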

Compound 3, concentration for 50% growth inhibition: 2950 nM
The estimate for compound 3 lay 4.1-fold (0.61 log units) above the measured number; the whole stated range lies above it.
By their numbers in this assay, from the lowest: compounds 2 and 3 (each within the scatter of the next); then compound 1.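

In this assay the 3-(4-chlorophenyl)-1,2,4-oxadiazol-5-yl group and the 5-phenyl-1,3,4-thiadiazol-2-yl group cannot be told apart at this position on the shared core, with a 1.6-fold higher number from compound 2 to compound 3 (0.20 log units; within the scatter). A chloro group on the outer phenyl ring therefore does not bring a high number in every setting: with that chloro group kept, putting the 3-(4-chlorophenyl)-1,2,4-oxadiazol-5-yl group in place of the 5-(4-chlorophenyl)-1,3,4-thiadiazol-2-yl group gives an 8.7-fold lower number from compound 1 to compound 3 (0.94 log units; beyond the scatter), so among these compounds the high number belongs to compound 1 alone. Nothing measured on these compounds accounts for this difference between the two five-membered rings.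

Still open, going by these compounds, is how a 3-phenyl-1,2,4-oxadiazol-5-yl group would compare with compound 3, and thus whether the chloro group makes any difference on the oxadiazole at all. Also open, on these data alone, is how an amine or a carboxylic acid in the place of that chloro group would read on either five-membered ring.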